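From methyl to methylsulfanyl: an expected small step

A few compounds are considered here, and "the series" means these few. Any claim that something is new, unique, unknown or untested is made for them only; others in the source may bear on it.

Compound 1, `NC(=O)c1c(NC(=O)c2ccccc2I)sc2c1CCN(C(=S)Nc1ccccc1Cl)C2`, gives 17500 nM in a functional assay on MKN-74 cells (Homo sapiens) for antiproliferative activity, with a stated time of 24 h; on this read-out lower numbers stand for stronger inhibition and higher numbers for weaker inhibition.
Compound 2, `NC(=O)c1c(NC(=O)c2ccccc2C(F)(F)F)sc2c1CCN(C(=S)Nc1ccccc1Cl)C2`, gives 21900 nM in this assay.
Compound 3, `Cc1ccccc1C(=O)Nc1sc2c(c1C(N)=O)CCN(C(=S)Nc1ccccc1Cl)C2`, gives 11000 nM in this assay.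

Compound 3 stands within the scatter of both other compounds, since its steps of a 1.6-fold lower number from compound 1 to compound 3 (0.20 log units; within the scatter) and a 2.0-fold lower number from compound 2 to compound 3 (0.30 log units; within the scatter) are too small to set it apart. Compound 4, `CSc1ccccc1C(=O)Nc1sc2c(c1C(N)=O)CCN(C(=S)Nc1ccccc1Cl)C2`, differs from compound 3 by a single change: methylsulfanyl in place of methyl on an aromatic carbon. The steps that touch the same position, a 1.3-fold higher number from compound 1 to compound 2 (0.10 log units; within the scatter), a 1.6-fold lower number from compound 1 to compound 3 (0.20 log units; within the scatter) and a 2.0-fold lower number from compound 2 to compound 3 (0.30 log units; within the scatter), all stayed within the scatter, so a further change at this place is expected to move this assay little, with no clear direction, estimated as a 1.1-fold higher number from compound 3 to compound 4 (0.04 log units; within the scatter). Compound 4 is therefore expected to give about 12000 nM, within a range from 5000 nM to 28000 nM.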

Compound 4, half-maximal inhibitory concentration: 6550 nM
Compound 4: middle estimate off by 1.8-fold (0.26 log units), on the high side, within the range that was stated.
By their numbers in this assay, from the lowest: compounds 4, 3, 1 and 2 (each within the scatter of the next, the first and the last beyond it).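

In this assay, this position now gives its first steps beyond the scatter: methylsulfanyl in place of trifluoromethyl gives a 3.3-fold lower number from compound 2 to compound 4 (0.52 log units; beyond the scatter) and methylsulfanyl in place of iodo gives a 2.7-fold lower number from compound 1 to compound 4 (0.43 log units; beyond the scatter), both modest. Methylsulfanyl in place of methyl gives a 1.7-fold lower number from compound 3 to compound 4 (0.23 log units; within the scatter) and so cannot be told apart from methyl here. No data are available to explain these differences. On these data alone, whether methoxy, ethylsulfanyl or an amine at this position would match methylsulfanyl remains open.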